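This account rests on a few compounds, and the source may have more. Where it says the series, first, only, none or still open, it means among the compounds named here.

Measured compounds:
compound 1 `Nc1ccccc1NC(=O)c1ccc(CSc2nccc(C(F)(F)F)n2)cc1` — 66.1%
compound 2 `COc1ccc(SCc2ccc(C(=O)Nc3ccccc3N)cc2)cc1` — 33.1%
compound 3 `Nc1ccccc1NC(=O)/C=C/c1ccc(CSc2ccc(C(F)(F)F)cn2)cc1` — 12.1%

In a functional assay on SMMC-7721 cells (Homo sapiens) for inhibition, read by CCK-8 assay, with a stated time of 72 h, tested at 2 uM (on this read-out lower numbers stand for less inhibition of growth and higher numbers for more inhibition of growth at the one concentration tested), compound 2 stands second highest of the three numbers. Its nearest neighbour is compound 3, whose value lies lower by a gap beyond the scatter; its furthest is compound 1, whose value lies higher, again beyond the scatter. Compound 4 `CCc1ccc(SCc2ccc(C(=O)Nc3ccccc3N)cc2)cc1` differs from compound 2 in one place: ethyl in place of methoxy on an aromatic carbon. Going by the values given here, no pair of measured compounds shows this change, so there is no measured step to lean on. The account therefore expects only a small shift, likely none beyond the scatter, in either direction. Compound 4 is estimated to give 35%, in a range from 18% to 55%. The expected step of a number 1.9 percentage points higher from compound 2 to compound 4 (within the scatter) is accordingly thought to be small.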

Compound 4, percent growth inhibition at one concentration: 25.7%
For compound 4 the middle estimate is 9.3 percentage points above the measured one; low and high end bracket the measured number.
By their numbers in this assay, from the lowest: compound 3; then compounds 4 and 2 (each within the scatter of the next); then compound 1.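

In this assay, going by these compounds alone, this position now has a measured step, a number 7.4 percentage points lower from compound 2 to compound 4 (within the scatter), which the earlier compounds could not supply. Within this one pair, the 4-methoxyphenyl to 4-ethylphenyl change, which removes the oxygen and the hydrogen-bond acceptor counted with it, does not separate the two compounds. Nothing given here explains this result.

Going by these compounds, whether an amine, a carboxylic acid or a longer chain at this place would give a step beyond the scatter stays open. On these data alone, whether ethyl in place of methoxy behaves the same way on another core is also open.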